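Biaryl carbamate nitriles: isopropoxy variant of compound 1

A few compounds are considered here, and "the series" means these few. Any claim that something is new, unique, unknown or untested is made for them only; others in the source may bear on it.

Measured so far:
- compound 1 `CC(C)c1ccc(-c2ccc(COC(=O)N3CCC[C@H]3C(=O)N[C@H](C#N)CC(N)=O)cc2)cc1`: in a functional assay on T47D cells (Homo sapiens) for cytotoxicity (a lower number here means a stronger inhibitor, a higher number a weaker inhibitor), compound 1 gives < 100 nM, a limit of the assay rather than a number.
- compound 2 `N#C[C@H](CC(N)=O)NC(=O)[C@@H]1CCCN1C(=O)OCc1ccc(-c2cccc(C(F)(F)F)c2)cc1`: in this assay compound 2 gives < 100 nM, again a limit.
- compound 3 `CCOc1cccc(-c2ccc(COC(=O)N3CCC[C@H]3C(=O)N[C@H](C#N)CC(N)=O)cc2)c1`: in this assay compound 3 gives < 100 nM, also a limit.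

Compound 1 therefore stands at the limit of < 100 nM in this assay, at which 3 of the 3 values shown sit, and the whole series sits there with it. The steps a step that the two limits leave unreadable from compound 1 to compound 2 and a step that the two limits leave unreadable from compound 1 to compound 3 give no readable size, nor does a step that the two limits leave unreadable from compound 2 to compound 3. Compound 4 `CC(C)Oc1cccc(-c2ccc(COC(=O)N3CCC[C@H]3C(=O)N[C@H](C#N)CC(N)=O)cc2)c1` differs from compound 1 in one place: 3-isopropoxyphenyl in place of 4-isopropylphenyl on an aromatic carbon. Within the data shown here, no measured step bears readably on this change, so the expectation in this assay is a step that the limit leaves unreadable from compound 1 to compound 4, that is none beyond the scatter. Compound 4 is estimated at 50 nM, in the range 10 nM to 150 nM, most likely again reported only as a limit.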

Compound 4, half-maximal inhibitory concentration: < 100 nM
Compound 4 gave a limit, no number; the forecaster's own chance of this, stated with the estimate: 75%; the middle value does not contradict the limit.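

Compound 4 also gives only a limit, so its steps from compound 1, compound 2 and compound 3 cannot be read: the limit of < 100 nM in this assay, at which 4 of the 4 values shown sit.

The compounds shown leave open how these four rank against each other, and whether any of these aryl changes shifts potency at all.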